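This account rests on a few compounds, and the source may have more. Where it says the series, first, only, none or still open, it means among the compounds named here.

Measured compounds:
compound 1 `Brc1ccc(N2CCCNCCC2)cn1`, 1.29 nM;
compound 2 `Oc1cncc(N2CCCNCC2)c1`, 141 nM;
compound 3 `Oc1cc(N2CCCNCC2)cnc1I`, 479 nM.

In a functional assay on HEK293 cells for agonist activity at Neuronal acetylcholine receptor; alpha4/beta2 (Homo sapiens), read by FLIPR and calcium flux (on this read-out lower numbers stand for an effect already at smaller amounts and higher numbers for an effect only at larger amounts of compound), compound 2 gives 141 nM, the second highest of the three numbers. Its nearest neighbour is compound 3, reached by a 3.4-fold higher number from compound 2 to compound 3 (0.53 log units; beyond the scatter), the two differing only in that compound 3 bears an iodo group where compound 2 bears hydrogen. Compound 1, which gives 1.29 nM, lies far lower. The unmeasured compound 4 `NC(=O)c1cncc(N2CCCNCC2)c1` differs from compound 2 as follows: carbamoyl in place of hydroxy on an aromatic carbon. No measured step tests this change; the only step shown concerns a different group, so the direction is open, though a shift beyond the scatter is plausible. Compound 4 is therefore estimated at 400 nM, within 80 nM to 2000 nM. For compound 4 this means an expected 2.8-fold higher number from compound 2 to compound 4 (0.45 log units; beyond the scatter).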

Compound 4, half-maximal effective concentration: 12900 nM
Estimate against measurement, compound 4: 32-fold (1.51 log units) below; the whole stated range lies below it.
By their numbers in this assay, from the lowest: compound 1; then compound 2; then compound 3; then compound 4.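

In this assay replacing hydroxy with carbamoyl, two atoms from the ring nitrogen, gives a 91-fold higher number from compound 2 to compound 4 (1.96 log units; beyond the scatter). For the compounds shown here, the only earlier step on this ring was the modest 3.4-fold higher number from compound 2 to compound 3 (0.53 log units; beyond the scatter), an iodo group replacing hydrogen, so this position can move the number much further than that one change did. Nothing available here explains the size of this step. From the compounds shown here alone, whether an amine or a carboxylic acid at this position would stay closer to compound 2 remains open. So does whether the extra atoms of carbamoyl or their particular arrangement matter more.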